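Moving a nitrogen into the pendant ring of two chalcone isomers

A few compounds are considered here, and "the series" means these few. Any claim that something is new, unique, unknown or untested is made for them only; others in the source may bear on it.

Measured compounds:
compound 1 `COc1ccc(/C=C/C(=O)c2ccccc2-c2ccc(F)cc2)cc1` — 670 nM
compound 2 `COc1ccc(/C=C/C(=O)c2ccccc2-c2ccc(F)nc2)cc1` — 2700 nM
compound 3 `COc1ccc(C(=O)/C=C/c2ccccc2-c2ccc(F)cc2)cc1` — 8800 nM

In a functional assay on MCF7 cells (Homo sapiens) for antiproliferative activity, read by sulforhodamine B assay, with a stated time of 48 h (a lower number here means a stronger inhibitor, a higher number a weaker inhibitor), compound 1 gives 670 nM, and its paired compound 2 gives 2700 nM. The step between them, a 4.0-fold higher number from compound 1 to compound 2 (0.61 log units; beyond the scatter), is the change (6-fluoropyridin-3-yl in place of 4-fluorophenyl on an aromatic carbon). Compound 3 shares all its atoms with compound 1 but joined differently; the difference between the two cores is not broken down here. In this assay compound 3 gives 8800 nM, the highest of the three numbers.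

Compound 4 `COc1ccc(C(=O)/C=C/c2ccccc2-c2ccc(F)nc2)cc1` is not yet measured. It arises from compound 3 by 6-fluoropyridin-3-yl in place of 4-fluorophenyl on an aromatic carbon, the same change seen from compound 1 to compound 2, placed on the same kind of position. Going by the values given here, compound 4 is expected to show a step of a 2.8-fold higher number from compound 3 to compound 4 (0.45 log units; beyond the scatter) in this assay, resting on a 4.0-fold higher number from compound 1 to compound 2 (0.61 log units; beyond the scatter) and on the single example available. Compound 4 is therefore estimated at 25000 nM, within 9000 nM to 70000 nM.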

Compound 4, half-maximal inhibitory concentration: 13000 nM
Estimate against measurement, compound 4: 1.9-fold (0.28 log units) above; the measured number falls inside the stated range.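

In this assay, placing 6-fluoropyridin-3-yl in place of 4-fluorophenyl on the core of compound 3 gives a 1.5-fold higher number from compound 3 to compound 4 (0.17 log units; within the scatter). This step lies within the scatter. The change therefore did not carry over at the same size from the core of compound 1 to the core of compound 3: the same change on two cores in this assay, a 4.0-fold higher number (0.61 log units; beyond the scatter) from compound 1 to compound 2 and a 1.5-fold higher number (0.17 log units; within the scatter) from compound 3 to compound 4, 2.7-fold (0.44 log units) apart, beyond the scatter of two such steps This rests on a single pair for each core, so it shows that the size of the step can depend on the core in these two cases, but not why it does or how the change would behave on any further core.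

The compounds shown leave open whether the two cores would also part in this way for a different pendant group, such as 4-chlorophenyl. They also leave open what an amine in place of the fluorine on the pendant ring would do on either core.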